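The compounds below may be only part of what the source reports. "The series", "measured", "known", "first", "only" and "open" are said of these compounds alone.

Measured so far in a functional assay on U2OS cells (Homo sapiens) for cytotoxicity, read by MTT assay, with a stated time of 48 h; a lower number here means a stronger inhibitor, a higher number a weaker inhibitor:
Compound 1 `Fc1ccc(Nc2nc(-c3cccc(F)c3)nc3ccc(F)cc23)cc1` gives > 50000 nM, a limit of the assay.
Compound 2 `Fc1cccc(-c2nc(Nc3ccccc3F)c3cc(F)ccc3n2)c1` gives > 50000 nM, again a limit.
Compound 3 `Fc1cccc(-c2nc(Nc3cccc(Cl)c3)c3cc(F)ccc3n2)c1` gives > 50000 nM, again a limit.

Compound 2 stands only at a limit in this assay; the two further values shown are limits as well, so it cannot be placed relative to compound 1 or compound 3. The whole picture is the limit of > 50000 nM in this assay, at which 3 of the 3 values shown sit. The steps between the measured compounds therefore carry no readable size: a step that the two limits leave unreadable from compound 1 to compound 2, a step that the two limits leave unreadable from compound 1 to compound 3, a step that the two limits leave unreadable from compound 2 to compound 3.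

Compound 4 `Nc1ccc(Nc2nc(-c3cccc(F)c3)nc3ccc(F)cc23)cc1` differs from compound 2 in one place: 4-aminophenyl in place of 2-fluorophenyl on a nitrogen on an aromatic ring. The three measured steps concern the same nitrogen on an aromatic ring, but none of them is readable, so no direction can be drawn for this assay, and nothing among the three limits gives a reason to expect compound 4 to leave the limit. The step is estimated as a number no higher from compound 2 to compound 4 (the limit leaves the size open). Compound 4 is expected to give 50000 nM, within a range of 20000 nM to 120000 nM, most likely reported as a limit once more.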

Compound 4, half-maximal inhibitory concentration: 44200 nM
Estimate against measurement, compound 4: 1.1-fold (0.05 log units) above; the measured number falls inside the stated range.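

In this assay, among the compounds shown here, compound 4 gives 44200 nM, the first read number at this nitrogen on an aromatic ring. The earlier compounds shown here gave only limits. Bringing in the 4-aminophenyl group gives an at least 1.1-fold lower number from compound 2 to compound 4 (0.05 log units; that floor lies within the scatter) and an at least 1.1-fold lower number from compound 3 to compound 4 (0.05 log units; that floor lies within the scatter), while amino in place of fluoro on an aromatic carbon gives an at least 1.1-fold lower number from compound 1 to compound 4 (0.05 log units; that floor lies within the scatter). These steps are floors only, and the rest of the series stays at one limit: the limit of > 50000 nM in this assay, at which 3 of the 4 values shown sit.

For the compounds shown here, how far the amino group moves the number cannot be read from these compounds, and neither can the earlier steps among the limits. Going by these compounds, how an acetamide or a carboxylic acid on the same aromatic carbon would read remains open.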